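A third hydroxy position on compound 1

The compounds below may be only part of what the source reports. "The series", "measured", "known", "first", "only" and "open" are said of these compounds alone.

In a functional assay on U-251 cells (Homo sapiens) for inhibition, read by sulforhodamine B assay, with a stated time of 48 h (a lower number here means a stronger inhibitor of growth, a higher number a weaker inhibitor of growth), compound 1 `CC1(/C=C/c2ccccc2)C=CC(=O)O1` gives 89800 nM and stands within the scatter of two hydroxy analogues: compound 2 `CC1(/C=C/c2ccccc2O)C=CC(=O)O1` gives 70900 nM and compound 3 `CC1(/C=C/c2cccc(O)c2)C=CC(=O)O1` gives 118000 nM in the same test. The next analogue, compound 4 `CC1(/C=C/c2ccc(O)cc2)C=CC(=O)O1`, differs from compound 1 by hydroxy in place of hydrogen on an aromatic carbon and has hydroxy in place of hydrogen on an aromatic carbon, para to a group of 9 heavy atoms. For the measured compounds named here, two measured steps bear on it, the same exchange at other aromatic carbons: a 1.3-fold lower number from compound 1 to compound 2 (0.10 log units; within the scatter) and a 1.3-fold higher number from compound 1 to compound 3 (0.12 log units; within the scatter) (both within the scatter). For compound 4 the estimated step in this assay is a 1.0-fold higher number from compound 1 to compound 4 (0.00 log units; within the scatter) (none beyond the scatter is expected). Compound 4 is estimated at 90000 nM (45000 nM to 150000 nM).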

Compound 4, concentration for total growth inhibition: 107000 nM
The estimate for compound 4 lay 1.2-fold (0.08 log units) below the measured number; the measured number falls inside the stated range.
By their numbers in this assay, from the lowest: compounds 2, 1, 4 and 3 (each within the scatter of the next).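

At the carbon para to a group of 9 heavy atoms, hydroxy in place of hydrogen gives a 1.2-fold higher number from compound 1 to compound 4 (0.08 log units; within the scatter) in this assay. This step also stays within the scatter, so compounds 2, 3 and 4 each remain within the scatter of compound 1, and the exchange has now been seen at a third aromatic carbon without a clear change in the number. Nothing available explains why these steps are so small. Still open, on these data alone, is whether a methoxy group, an amine or a carboxylic acid at this carbon would give a step beyond the scatter.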